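Replacing 3,4-dimethoxyphenyl in a growth inhibitor series

The source may hold more compounds than are shown below. What is called first, only, known or untested is meant among the compounds shown, and "the series" means these compounds.

Measured in a functional assay on SiHa cells (Homo sapiens) for inhibition, read by sulforhodamine B assay; a lower number here means a stronger inhibitor of growth, a higher number a weaker inhibitor of growth:
compound 1 `COc1ccc(-c2ccc(-c3ccc(-c4nc5cc(C)ccc5[nH]4)cc3)cc2)cc1OC`: 3510 nM
compound 2 `COc1cc(-c2ccc(-c3ccc(-c4nc5cc(C)ccc5[nH]4)cc3)cc2)cc(OC)c1OC`: 170 nM
compound 3 `COc1ccc(-c2ccc(-c3ccc(-c4nc5c(O)cccc5[nH]4)cc3)cc2)cc1OC`: 1110 nM

Compound 1 has the highest number of the three and is the weakest inhibitor of growth here, with its steps to both others beyond the scatter. The next compound, compound 4 `Cc1ccc2[nH]c(-c3ccc(-c4ccc(-c5ccc(OC(F)(F)F)cc5)cc4)cc3)nc2c1`, carries 4-(trifluoromethoxy)phenyl in place of 3,4-dimethoxyphenyl on an aromatic carbon, para to a large group: 4-(trifluoromethoxy)phenyl in place of 3,4-dimethoxyphenyl on an aromatic carbon.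

For the measured compounds named here, no measured step makes this exchange. The nearest evidence is a 21-fold lower number from compound 1 to compound 2 (1.31 log units; beyond the scatter), where one methoxy is added to the group that leaves here, so this assay responds strongly to changes in this group. That step adds a methoxy, whereas this change removes both, so its direction does not carry over. The step of a 3.2-fold lower number from compound 1 to compound 3 (0.50 log units; beyond the scatter) leaves this group untouched and bears only on how much the series can move.

An estimated step of a 1.4-fold lower number from compound 1 to compound 4 (0.15 log units; within the scatter) is expected, not clearly beyond the scatter. For compound 4 the expected value is 2500 nM, with an estimated range of 600 nM to 9000 nM.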

Compound 4, concentration for 50% growth inhibition: 28300 nM
Compound 4: the middle estimate sits 11-fold (1.05 log units) below what was measured; the whole stated range lies below it.
By their numbers in this assay, from the lowest: compound 2; then compound 3; then compound 1; then compound 4.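

In this assay, 4-(trifluoromethoxy)phenyl in place of 3,4-dimethoxyphenyl gives an 8.1-fold higher number from compound 1 to compound 4 (0.91 log units; beyond the scatter), whereas the earlier step at this group, a 21-fold lower number from compound 1 to compound 2 (1.31 log units; beyond the scatter), went the other way. This position on an aromatic carbon, para to a large group, therefore moves growth inhibition in either direction, and this exchange costs activity against the 3,4-dimethoxyphenyl group. The step removes the methoxy groups and brings in trifluoromethoxy at once, and nothing available accounts for the loss.

The compounds shown do not separate the loss of the methoxy groups from the entry of trifluoromethoxy, a question that 4-methoxyphenyl or unsubstituted phenyl at this position would address. Also open, as far as these compounds go, are whether an amine here would be tolerated and whether the exchange costs as much alongside the 4-hydroxy-1H-benzimidazol-2-yl group of compound 3.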